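The compounds below may be only part of what the source reports. "The series", "measured", "known", "first", "only" and "open" are said of these compounds alone.

Measured in a functional assay on SiHa cells (Homo sapiens) for inhibition, read by sulforhodamine B assay; a higher number here means a weaker inhibitor of growth, a lower number a stronger inhibitor of growth:
- compound 1 `c1ccc(-c2ccc(-c3ccc(-c4nc5ccccc5[nH]4)cc3)cc2)cc1`: 100000 nM
- compound 2 `FC(F)(F)Oc1ccc(-c2ccc(-c3ccc(-c4nc5ccccc5[nH]4)cc3)cc2)cc1`: 38400 nM
- compound 3 `Oc1ccc(-c2ccc(-c3ccc(-c4nc5ccccc5[nH]4)cc3)cc2)cc1`: 33300 nM

Compound 3 stands at the low end of these three values, but not alone. The nearest gap is a 1.2-fold lower number from compound 2 to compound 3 (0.06 log units; within the scatter). The widest gap is a 3.0-fold lower number from compound 1 to compound 3 (0.48 log units; beyond the scatter).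

Compound 4 `Cc1ccc2[nH]c(-c3ccc(-c4ccc(-c5ccc(O)cc5)cc4)cc3)nc2c1` differs from compound 3 by a single change, methyl in place of hydrogen on an aromatic carbon. The carbon belongs to a six-membered aromatic ring of carbon only, part of a fused or bridged system of two rings.

Going by the values given here, no measured compound carries a methyl, and no measured step changes this ring system, so the evidence is only indirect. The two single substitutions on compound 1 elsewhere in the molecule were modest: a 2.6-fold lower number from compound 1 to compound 2 (0.42 log units; beyond the scatter), and a 3.0-fold lower number from compound 1 to compound 3 (0.48 log units; beyond the scatter). Exchanging one of those substituents for the other made no difference beyond the scatter, as a 1.2-fold lower number from compound 2 to compound 3 (0.06 log units; within the scatter) shows. A small step is therefore expected in this assay, most likely within the scatter and with no firm direction. The expected step is a 1.2-fold lower number from compound 3 to compound 4 (0.08 log units; within the scatter). For compound 4 the estimated value is 28000 nM, with an expected range from 11000 nM to 65000 nM.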

Compound 4, concentration for 50% growth inhibition: 33500 nM
The estimate for compound 4 lay 1.2-fold (0.08 log units) below the measured number, and the stated range covers the measured number.
By their numbers in this assay, from the lowest: compounds 3, 4 and 2 (each within the scatter of the next); then compound 1.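

In this assay, compound 4 is the only one shown with a change on the fused ring system rather than elsewhere in the molecule, and the step is a 1.0-fold higher number from compound 3 to compound 4 (0.00 log units; within the scatter). Going by these compounds alone, this shows that, with the hydroxy group of compound 3 in place, this aromatic carbon of the six-membered aromatic ring of carbon only can carry a methyl instead of a hydrogen without a change in the number beyond the scatter, something the earlier steps, all made elsewhere in the molecule, could not show. No measurement shown here explains why this single added carbon leaves the reading where it is.

What the compounds leave open is whether this carbon is as tolerant of other groups, such as a chlorine, a methoxy group, an amine or a carboxylic acid, since a methyl is the only replacement for hydrogen seen here. Going by these compounds, it also remains open whether the same methyl would behave alike on compound 1, which lacks the hydroxy group, or on compound 2, which carries trifluoromethoxy in its place.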